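Swapping a Chloro for an Isopropyl on a Hydroxamic Acid

A few compounds are considered here, and "the series" means these few. Any claim that something is new, unique, unknown or untested is made for them only; others in the source may bear on it.

Among the measured compounds shown here, compound 2 `O=C(/C=C/c1ccc(/C=C/C(=O)c2ccc(Cl)cc2)o1)NO` stands at the lower of the two numbers measured so far: in a functional assay on PC-3 cells (Homo sapiens) for antiproliferative activity, read by MTT assay, with a stated time of 48 h (a lower number here means a stronger inhibitor, a higher number a weaker inhibitor), compound 2 gives 1350 nM. Its only measured companion, compound 1 `O=C(/C=C/c1ccc(/C=C/C(=O)c2cc(Cl)ccc2Cl)o1)NO`, is a markedly weaker inhibitor, since in this assay compound 1 gives 24700 nM, a gap well beyond the usual scatter. Compound 3 `CC(C)c1ccc(C(=O)/C=C/c2ccc(/C=C/C(=O)NO)o2)cc1` has not yet been measured. It differs from compound 2 in one place: isopropyl in place of chloro on an aromatic carbon. The swap sits on an aromatic carbon of a six-membered aromatic ring of carbon only, para to a large group. For the measured compounds named here, no measured pair shows a swap of this kind, so there is no earlier step to lean on, and the expected step from compound 2 to compound 3 is a 1.6-fold higher number from compound 2 to compound 3 (0.21 log units; within the scatter), a modest weakening at most. Compound 3 is therefore estimated at 2200 nM in this assay, with a range from 600 nM to 8000 nM.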

Compound 3, half-maximal inhibitory concentration: 2270 nM
Compound 3: middle estimate off by 1.0-fold (0.01 log units), on the low side; low and high end bracket the measured number.
By their numbers in this assay, from the lowest: compounds 2 and 3 (each within the scatter of the next); then compound 1.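

In this assay the swap of chloro for isopropyl gives a 1.7-fold higher number from compound 2 to compound 3 (0.23 log units; within the scatter) and so leaves the read-out the same within the usual scatter. Among the compounds shown here, this is the first single swap that can be read at this place, an aromatic carbon para to a large group, and it shows that 3 heavy atoms of carbon can stand where 1 chlorine stood with no change beyond that scatter. Nothing at hand explains why these two groups read alike.

As far as these compounds go, it remains open whether this tolerance extends to groups of a different kind, such as an amine, a carboxylic acid or a longer chain on the same aromatic carbon. From the compounds shown here alone, it also remains open whether compound 2 and compound 3 would stay this close in a test on other cells.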